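Extending the Amino Group of a Purine-Type TLR9 Antagonist

The source may report more compounds than this note shows. Statements on the series, on what has been measured and on what is new or still open speak of the compounds shown alone.

Measured compounds:
compound 1, `CCN1CCN(CCCn2cnc3c(N4CCN(C5CCCC5)CC4)nc(N)nc32)CC1`: 280 nM
compound 2, `CCN1CCN(CCCn2cnc3c(N4CCN(C(=O)C5CCCC5)CC4)nc(N)nc32)CC1`: > 30000 nM
compound 3, `Nc1nc(N2CCN(C3CCCC3)CC2)c2ncn(CCCN3CCCC3)c2n1`: 120 nM

In an assay on HEK293 cells for antagonist activity at Toll-like receptor 9 (Homo sapiens), read by spectrophotometry (a lower number here means a stronger inhibitor, a higher number a weaker inhibitor), compound 1 gives 280 nM. Among the measured compounds it has the highest of the two reported numbers; compound 3 gives 120 nM, which is a 2.3-fold lower number from compound 1 to compound 3 (0.37 log units; beyond the scatter). The value of compound 2 is a limit of this assay and not a number; compound 2 sits at the limit of > 30000 nM in this assay, at which 1 of the 3 values shown sits. Two single changes have thus been made from compound 1: an at least 100-fold higher number from compound 1 to compound 2 (2.02 log units; beyond the scatter), and the modest change to compound 3 just described.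

Compound 4, `CCN1CCN(CCCn2cnc3c(N4CCN(C5CCCC5)CC4)nc(NCc4ccc(OC)cc4)nc32)CC1`, differs from compound 1 in a different part of the shared core: 4-methoxybenzyl in place of hydrogen on a nitrogen on an aromatic ring. Within the data shown here, neither measured step touches this amino group, so no measured step bears directly on the change, and the existing data give no direction to expect. The acyl step to compound 2 shows that this assay can react strongly to some changes, which argues for a wide range. Compound 4 is expected to give about 400 nM, with a range of 80 nM to 3000 nM. The expected step is a 1.4-fold higher number from compound 1 to compound 4 (0.15 log units; within the scatter), not beyond the scatter.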

Compound 4, half-maximal inhibitory concentration: 120 nM
Beside the measured number, compound 4's estimate is 3.3-fold (0.52 log units) above it; the measured number falls inside the stated range.
By their numbers in this assay, from the lowest: compounds 3 and 4 (each within the scatter of the next); then compound 1. At a limit, above all of these: compound 2.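

Among these compounds, until now, the amino group of the shared core was untouched, so this is the first reading of what a change at that nitrogen does. Putting 4-methoxybenzyl in place of hydrogen there gives a 2.3-fold lower number from compound 1 to compound 4 (0.37 log units; beyond the scatter) in this assay, which shows that this nitrogen can carry a large group, with 9 heavy atoms and a six-membered aromatic ring, and still give a stronger inhibitor than the parent. Nothing in the data shown explains how this group produces the modest step, and the only supporting note concerns the limit reached by compound 2, at a different place on the molecule.

On these data alone, it remains open which part of the new group matters: a plain benzyl, a small methyl or a longer chain such as 2-phenylethyl on the same nitrogen would separate the effect of the aromatic ring and its methoxy group from that of size alone. It is also open whether this change adds to the swap of 4-ethylpiperazin-1-yl for pyrrolidin-1-yl on the chain, since a compound carrying 4-methoxybenzyl together with pyrrolidin-1-yl is not among those shown.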